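Fluoro for Chloro in a Weakly Growth-Inhibiting Sulfone

The source may report more compounds than this note shows. Statements on the series, on what has been measured and on what is new or still open speak of the compounds shown alone.

Measured compounds:
compound 1 `O=C(/C(=C\c1ccc(Cl)cc1)S(=O)(=O)c1ccc(Br)cc1)c1ccc(Br)cc1` with 50000 nM
compound 2 `COc1cc(OC)c(/C=C(\SCc2ccccc2Cl)C(=O)c2ccc(Cl)cc2)c(OC)c1` with 25000 nM
compound 3 `COc1ccc(S/C(=C/c2ccc(Br)cc2)C(=O)c2ccc(Br)cc2)cc1` with 20000 nM

In a functional assay on DU-145 cells (Homo sapiens) for inhibition, read by trypan blue exclusion, with a stated time of 96 h (on this read-out lower numbers stand for stronger inhibition of growth and higher numbers for weaker inhibition of growth), compound 1 gives the highest number of the three, so it is the weakest inhibitor of growth among them; its gap to compound 2 lies within the usual scatter, while its gap to compound 3 is beyond it. For the measured compounds named here, no pair of compounds differing in one place has been measured, so no step can be read from the numbers. Compound 4 `O=C(/C(=C\c1ccc(F)cc1)S(=O)(=O)c1ccc(Br)cc1)c1ccc(Br)cc1` differs from compound 1 as fluoro in place of chloro on an aromatic carbon. Going by the values given here, with no measured step to lean on, a change of this size is expected to give no step beyond the scatter. Compound 4 is therefore estimated at 50000 nM, between 20000 nM and 125000 nM, a step of no change at the digits printed from compound 1 to compound 4 (within the scatter).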

Compound 4, concentration for 50% growth inhibition: 4000 nM
For compound 4 the middle estimate is 13-fold (1.10 log units) above the measured one; measured number outside the range, below it.
By their numbers in this assay, from the lowest: compound 4; then compounds 3, 2 and 1 (each within the scatter of the next, the first and the last beyond it).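

For the compounds shown here, this is the first step that can be read here, and it shows that the halogen on this aromatic carbon matters: in this assay, going from 4-chlorophenyl to 4-fluorophenyl gives a 13-fold lower number from compound 1 to compound 4 (1.10 log units; beyond the scatter) with stronger inhibition of growth. One heavy atom replaces another, with no change in ring, charge, or hydrogen-bond donor and acceptor counts, yet the step lies well beyond the scatter. No measurement shown accounts for this step.

Going by these compounds, it remains open how an amine or a nitrile at this position would compare with fluoro. On these data alone, it is also open whether fluoro in place of chloro would give a similar step elsewhere on the core.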